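Amide substituent change from compound 2 to compound 3

The source may hold more compounds than are shown below. What is called first, only, known or untested is meant among the compounds shown, and "the series" means these compounds.

In a physicochemical assay for solubility, read by spectrophotometry, measured as kinetic solubility, at pH 8, tested at 500 uM (on this read-out lower numbers stand for lower solubility and higher numbers for higher solubility), compound 1 `Cn1cc(NC(=O)c2ccncc2Nc2cc(-c3ccc4ccn(C)c4c3)c3nccnc3c2)cn1` gives 2 ug/mL and compound 2 `Cn1cc(CNC(=O)c2ccncc2Nc2cc(-c3ccc4ccn(C)c4c3)c3nccnc3c2)cn1` gives 127 ug/mL, the higher of the two numbers. Among the measured compounds shown here, the only measured step, a 64-fold higher number from compound 1 to compound 2 (1.80 log units; beyond the scatter), is large and beyond the scatter, and it sits on the same amide-type nitrogen. Compound 3 `CC(=O)N1CCC(NC(=O)c2ccncc2Nc2cc(-c3ccc4ccn(C)c4c3)c3nccnc3c2)CC1` differs from compound 2 as follows: 1-acetylpiperidin-4-yl in place of (1-methyl-1H-pyrazol-4-yl)methyl on an amide-type nitrogen. For the measured compounds named here, no measured compound yet carries 1-acetylpiperidin-4-yl, so that step guides only loosely. The expected change is small, with none beyond the scatter: a 1.4-fold lower number from compound 2 to compound 3 (0.15 log units; within the scatter). The estimated value for compound 3 is 90 ug/mL, with a range of 25 ug/mL to 240 ug/mL.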

Compound 3, solubility: 213 ug/mL
Compound 3: the middle estimate sits 2.4-fold (0.37 log units) below what was measured; the measured number falls inside the stated range.
By their numbers in this assay, from the lowest: compound 1; then compounds 2 and 3 (each within the scatter of the next).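

In this assay, 1-acetylpiperidin-4-yl on the amide-type nitrogen reads level with (1-methyl-1H-pyrazol-4-yl)methyl (a 1.7-fold higher number from compound 2 to compound 3 (0.22 log units; within the scatter)). Against 1-methyl-1H-pyrazol-4-yl, the same group gives a large step (a 110-fold higher number from compound 1 to compound 3 (2.03 log units; beyond the scatter)), so a large step at this nitrogen no longer rests on the pyrazole-bearing group of compound 2 alone. No measurement shown accounts for either step. Open is whether the acetyl matters, since a piperidin-4-yl with a free ring amine is not among these compounds. As far as these compounds go, a longer chain between the nitrogen and the pyrazole also remains untested here.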